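This account rests on a few compounds, and the source may have more. Where it says the series, first, only, none or still open, it means among the compounds named here.

Working notes on the series. In a functional assay on Raji cells (Homo sapiens) for inhibition (on this read-out higher numbers stand for weaker inhibition and lower numbers for stronger inhibition), compound 1 `COc1cccc(OC/C=C(\C)CC/C=C(\C)C2CC(=O)C(C)(C)O2)c1` gives 50 ug/mL, compound 2 `C/C(=C\COc1ccccc1)CC/C=C(\C)C1CC(=O)C(C)(C)O1` gives 50.7 ug/mL, and compound 3 `C/C(=C\COc1c(Cl)cccc1Cl)CC/C=C(\C)C1=CC(=O)C(C)(C)O1` gives 26.2 ug/mL. Compound 3 carries the lowest of the three numbers, but its gaps to compound 1 and to compound 2 both lie within the scatter, so no order among the three can be read from these figures. Among the measured compounds shown here, the only single-point step measured so far, a 1.0-fold higher number from compound 1 to compound 2 (0.01 log units; within the scatter), concerns a substituent on the aromatic ring and stayed within the scatter.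

Compound 4 `COc1cccc(OC/C=C(\C)CC/C=C(\C)C2=CC(=O)C(C)(C)O2)c1` is not yet measured. Against compound 3 it shows (3-methoxyphenyl in place of 2,6-dichlorophenyl on an oxygen on a saturated carbon). For the measured compounds named here, no measured step exchanges one aryl group for another, so the evidence bearing on this change is indirect: the one aryl-substituent step available stayed within the scatter, and compound 4 shares its aryl ether with compound 1, whose number sits close to that of compound 3. The step expected is a 1.3-fold higher number from compound 3 to compound 4 (0.13 log units; within the scatter), nothing beyond the scatter in this assay. Compound 4 is therefore estimated to give 35 ug/mL, within a range from 15 ug/mL to 80 ug/mL.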

Compound 4, half-maximal inhibitory concentration: 45.8 ug/mL
Estimate against measurement, compound 4: 1.3-fold (0.12 log units) below; low and high end bracket the measured number.
By their numbers in this assay, from the lowest: compounds 3, 4, 1 and 2 (each within the scatter of the next).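

In this assay, the exchange of aryl groups on the oxygen is now measured directly, and it gives a 1.7-fold higher number from compound 3 to compound 4 (0.24 log units; within the scatter) without a readable change at this position for this pair. The other new step, a 1.1-fold lower number from compound 1 to compound 4 (0.04 log units; within the scatter) for one five-membered non-aromatic ring with one hetero atom in place of another of the same heavy-atom count, shows that this second site also stays within the scatter for the 3-methoxyphenyl ethers. No independent evidence bears on these results.

Among the compounds shown here, whether any group on this oxygen can move the number beyond the scatter remains open, since every measured step so far stays within it. An amine or a carboxylic acid in place of the aryl group would test this position more widely.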